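Cyclopropyl in Place of Methyl on a Sulfonyl Sulfur

The compounds below may be only part of what the source reports. "The series", "measured", "known", "first", "only" and "open" are said of these compounds alone.

- Compound 1 `CC(C)COc1ncc(-c2cn(C)c3cc(C(=O)NS(=O)(=O)C4CC4)c(F)cc23)cc1Cl`: 100%
- Compound 2 `CC(C)COc1ccc(-c2cn(C)c3cc(C(=O)NS(C)(=O)=O)c(F)cc23)cn1`: 98%
- Compound 3 `CC(C)COc1ncc(-c2cn(C)c3cc(C(=O)NS(C)(=O)=O)c(F)cc23)cc1Cl`: 100%

In an ADME assay on microsomes from liver (Homo sapiens) for metabolic stability, with a stated time of 10 min, tested at 0.5 uM (a higher number here means that more of the compound is left, a lower number that less of the compound is left), compound 2 gives 98%, within the scatter of both other compounds. Compound 4 `CC(C)COc1ccc(-c2cn(C)c3cc(C(=O)NS(=O)(=O)C4CC4)c(F)cc23)cn1` carries cyclopropyl in place of methyl on a sulfonyl sulfur. The same exchange, read in reverse, is seen among the chloro compounds, with no change at the digits printed from compound 1 to compound 3 (within the scatter). Chloro in place of hydrogen also gives a small step, with a number 2 percentage points higher from compound 2 to compound 3 (within the scatter). Neither step leaves the scatter, so no step beyond the scatter is expected in this assay, in either direction. The expected change is no change at the digits printed from compound 2 to compound 4 (within the scatter). For compound 4 the estimated value is 98%, with an expected range from 91% to 100%.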

Compound 4, percent of the compound remaining: 100%
Compound 4: the middle estimate sits 2 percentage points below what was measured; low and high end bracket the measured number.
By their numbers in this assay, from the lowest: compounds 2, 1, 3 and 4 (each within the scatter of the next).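

In this assay, cyclopropyl in place of methyl on a sulfonyl sulfur can now be read on the core without chloro, giving a number 2 percentage points higher from compound 2 to compound 4 (within the scatter). Hydrogen in place of chloro on an aromatic carbon gives no change at the digits printed from compound 1 to compound 4 (within the scatter), which completes a square of four compounds, and the sulfonyl change reads alike on both cores: the same change on two cores in this assay, no change at the digits printed (within the scatter) from compound 1 to compound 3 and a number 2 percentage points lower (within the scatter) from compound 4 to compound 2, 2 percentage points apart, within the scatter of two such steps The chloro change also reads alike on both cores: the same change on two cores in this assay, a number 2 percentage points higher (within the scatter) from compound 2 to compound 3 and no change at the digits printed (within the scatter) from compound 4 to compound 1, 2 percentage points apart, within the scatter of two such steps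

Whether a phenyl group, a longer chain or an amine on the sulfonyl sulfur would stay within the scatter of these compounds remains open.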